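From cyclopentylsulfonyl to cyclopropylcarbonyl on the shared core

A few compounds are considered here, and "the series" means these few. Any claim that something is new, unique, unknown or untested is made for them only; others in the source may bear on it.

Measured in a functional assay on HeLa cells (Homo sapiens) for antiproliferative activity, read by MTT assay, with a stated time of 48 h; a higher number here means a weaker inhibitor, a lower number a stronger inhibitor:
- Compound 1 `COc1ccc(-c2cn3cc(C4=CCN(C(=O)c5ccccc5C(F)(F)F)CC4)ccc3n2)cc1OC`: 7950 nM
- Compound 2 `COc1ccc(-c2cn3cc(C4=CCN(C(=O)c5ccc(Cl)cc5)CC4)ccc3n2)cc1OC`: 12200 nM
- Compound 3 `COc1ccc(-c2cn3cc(C4=CCN(S(=O)(=O)C5CCCC5)CC4)ccc3n2)cc1OC`: 6470 nM

Compound 3, at 6470 nM, lies within the scatter of both compound 1 and compound 2, so the three cannot be ranked. Compound 4 `COc1ccc(-c2cn3cc(C4=CCN(C(=O)C5CC5)CC4)ccc3n2)cc1OC` has not yet been measured. It differs from compound 3 by one change, cyclopropylcarbonyl in place of cyclopentylsulfonyl on an amine nitrogen in a ring.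

The closest evidence comes from two steps that exchange a carbonyl group for cyclopentylsulfonyl at that nitrogen: a 1.2-fold lower number from compound 1 to compound 3 (0.09 log units; within the scatter) and a 1.9-fold lower number from compound 2 to compound 3 (0.28 log units; within the scatter). Exchanging one carbonyl group for another gave a 1.5-fold higher number from compound 1 to compound 2 (0.19 log units; within the scatter). Among the measured compounds shown here, all three remain within the scatter, although no measured compound carries cyclopropylcarbonyl. No step beyond the scatter is therefore expected in this assay. The estimated step is a 1.3-fold higher number from compound 3 to compound 4 (0.12 log units; within the scatter). For compound 4 the estimated value is 8500 nM, with an expected range of 4200 nM to 18000 nM.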

Compound 4, half-maximal inhibitory concentration: 15800 nM
Compound 4: middle estimate off by 1.9-fold (0.27 log units), on the low side, within the range that was stated.
By their numbers in this assay, from the lowest: compounds 3, 1, 2 and 4 (each within the scatter of the next, the first and the last beyond it).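

Among the compounds shown here, at this amine nitrogen in a ring, cyclopropylcarbonyl in place of cyclopentylsulfonyl gave the first step beyond the scatter in this assay, with a 2.4-fold higher number from compound 3 to compound 4 (0.39 log units; beyond the scatter) on record. Against the two aryl carbonyl compounds, cyclopropyl on the carbonyl carbon gave a 1.3-fold higher number from compound 2 to compound 4 (0.11 log units; within the scatter) and a 2.0-fold higher number from compound 1 to compound 4 (0.30 log units; within the scatter), both within the scatter, so compound 4 cannot be separated from either of them, and only compound 3 stands apart from it. Nothing among the data shown accounts for this step.

Compound 3 and compound 4 differ in both the sulfonyl or carbonyl link and the carbon ring, so the compounds shown do not say which of the two carries the step. From the compounds shown here alone, a cyclopentylcarbonyl or cyclopropylsulfonyl group at this nitrogen would separate them, and how an acetyl group or the free amine would stand there remains open.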